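The source may report more compounds than this note shows. Statements on the series, on what has been measured and on what is new or still open speak of the compounds shown alone.

The series shares one core, shown by compound 1 `CCCS(=O)(=O)c1ccc(F)c(C#Cc2cc(Cl)ccc2OCC(=O)O)c1`, compound 2 `COCCNS(=O)(=O)c1ccc(C)c(C#Cc2cc(Cl)ccc2OCC(=O)O)c1` and compound 3 `Cc1ccc(S(=O)(=O)N(C)C)cc1C#Cc1cc(Cl)ccc1OCC(=O)O`, and differs in the group carried on the sulfonyl sulfur and in the substituent on the ring next to it. In an ADME assay on a cell-free system (plasma, Rattus norvegicus) (on this read-out lower numbers stand for a smaller free fraction and higher numbers for a larger free fraction), compound 1 gives 0.004. For compound 2 the outcome in this assay is "not determined" (no result reported), so no number marks where compound 2 stands, and the only anchor for the series is the value of compound 1.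

The step from compound 2 to compound 3 is a single change: dimethylamino in place of (2-methoxyethyl)amino on a sulfonyl sulfur. For the measured compounds named here, with no measured pair to compare, no size can be assigned to this step in this assay from the data; the expectation is for no shift beyond the usual scatter in either direction.

Compound 3 is therefore expected, on the strength of compound 1 with its 0.004, to show an unbound fraction of 0.005 in this assay, estimated to lie between 0.002 and 0.015.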

Compound 3, unbound fraction: 0.004
Compound 3: the middle estimate sits 1.3-fold (0.10 log units) above what was measured, and the stated range covers the measured number.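

No new step can be read in this assay: compound 2 has no number to set against compound 3, and compound 1 and compound 3 differ in more than one place. Nothing at hand bears on the result for compound 3. The compounds shown leave open what dimethylamino in place of (2-methoxyethyl)amino on a sulfonyl sulfur does to the unbound fraction.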